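The compounds below may be only part of what the source reports. "The series", "measured", "known", "first", "only" and "open" are said of these compounds alone.

Values so far in a functional assay (trachea) with Cavia porcellus as the target; on this read-out lower numbers stand for stronger inhibition and higher numbers for weaker inhibition
compound 1 `CCn1nc(-c2cccnc2)c2ccccc2c1=O` gives 1320 nM
compound 2 `CCCn1nc(-c2cccnc2)c2ccccc2c1=O` gives 3160 nM

Compound 2 carries the higher number of the two and so stands as the weaker inhibitor. Compound 3 `CCCCn1nc(-c2cccnc2)c2ccccc2c1=O` differs from compound 2 by methyl in place of hydrogen on a saturated chain carbon, three bonds along the chain from an aromatic nitrogen. The change is propyl to butyl, with methyl in place of hydrogen on a saturated chain carbon, three bonds along the chain from an aromatic nitrogen. Among the measured compounds shown here, the one measured step of this kind is a 2.4-fold higher number from compound 1 to compound 2 (0.38 log units; beyond the scatter) and counts as modest. A step of similar size toward a higher number is therefore expected in this assay on this single precedent. The expected step is a 1.6-fold higher number from compound 2 to compound 3 (0.20 log units; within the scatter) and carries wide uncertainty. For compound 3 the estimate is 5000 nM within an expected range of 1800 nM to 13000 nM.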

Compound 3, half-maximal inhibitory concentration: 2290 nM
Compound 3: middle estimate off by 2.2-fold (0.34 log units), on the high side, within the range that was stated.
By their numbers in this assay, from the lowest: compounds 1, 3 and 2 (each within the scatter of the next, the first and the last beyond it).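

In this assay, the propyl to butyl change gives a 1.4-fold lower number from compound 2 to compound 3 (0.14 log units; within the scatter), so the rise seen with a 2.4-fold higher number from compound 1 to compound 2 (0.38 log units; beyond the scatter) does not clearly continue at this position. Read across the whole change, a 1.7-fold higher number from compound 1 to compound 3 (0.24 log units; within the scatter), which leaves compound 3 inseparable from both of the others, even though compound 1 and compound 2 stand apart. No supporting data bear on this result.

As far as these compounds go, whether a longer chain such as pentyl or hexyl stays in this same span remains open. So does the outcome of placing an amine or a carboxylic acid at the end of the chain.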